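The source may report more compounds than this note shows. Statements on the series, on what has been measured and on what is new or still open speak of the compounds shown alone.

In a functional assay on K562 cells (Homo sapiens) for antiproliferative activity, read by MTT assay, with a stated time of 24 h (on this read-out higher numbers stand for weaker inhibition and lower numbers for stronger inhibition), compound 1 (`COc1ccc(C(=O)/C=C/c2ccc(F)cc2)c2c1C=CC(C)(C)O2`) gives > 10000 nM as a limit of the assay and not a number. Compound 2 (`COc1ccc(C(=O)/C=C/c2ccsc2)c2c1C=CC(C)(C)O2`) gives > 10000 nM and this too is only a limit. Compound 2 therefore has no readable number, and the same holds for everything measured so far (the limit of > 10000 nM in this assay, at which 2 of the 2 values shown sit). Compound 3 (`COc1ccc(C(=O)/C=C/c2ccccn2)c2c1C=CC(C)(C)O2`) carries pyridin-2-yl in place of thiophen-3-yl on a double-bonded chain carbon bound to a double-bonded chain carbon. Among the measured compounds shown here, the one measured step that bears on this change also swaps one ring group for another at that place (a step that the two limits leave unreadable from compound 1 to compound 2) and it offers no size to carry over. Since compound 2 rests at > 10000 nM as a limit, no step beyond the scatter is expected in either direction. The estimated step is small (a step that the limit leaves unreadable from compound 2 to compound 3). For compound 3 the expected value is 12000 nM with an estimated range of 4000 nM to 30000 nM around it.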

Compound 3, half-maximal inhibitory concentration: 5400 nM
For compound 3 the middle estimate is 2.2-fold (0.35 log units) above the measured one; the range from low to high includes it.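

this assay now has its first readable number at this place on the double-bonded chain carbon: compound 3 gives 5400 nM, so a ring swap here can bring the value inside the measurable range. Pyridin-2-yl gives an at least 1.8-fold lower number from compound 2 to compound 3 (0.26 log units; that floor lies within the scatter) and an at least 1.8-fold lower number from compound 1 to compound 3 (0.26 log units; that floor lies within the scatter); these are only floors, and the step between the other two compounds cannot be read. Every comparison so far therefore rests on a limit: the limit of > 10000 nM in this assay, at which 2 of the 3 values shown sit.

The change from thiophen-3-yl to pyridin-2-yl alters both the ring size and the hetero atom, so these compounds cannot show which of the two matters. As far as these compounds go, it also remains open whether pyridin-4-yl, or a 4-aminophenyl group, at the same place would give a lower number than compound 3.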